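The source may hold more compounds than are shown below. What is called first, only, known or untested is meant among the compounds shown, and "the series" means these compounds.

Measured so far:
compound 1 `Cc1nc2ccccc2nc1OCC(=O)Nc1ccc(Cl)cc1` — > 100000 nM
compound 2 `Cc1ccc(NC(=O)COc2nc3ccccc3nc2/C=C\c2ccncc2)cc1` — > 100000 nM

The series is read in a functional assay on HeLa cells (Homo sapiens) for inhibition, read by MTT assay, with a stated time of 24 h; a higher number here means a weaker inhibitor, a lower number a stronger inhibitor. Compound 1 gives only a limit in this assay, > 100000 nM. Compound 2 likewise gives only a limit, > 100000 nM. Among the compounds with values here, both values therefore sit at the limit of > 100000 nM in this assay, at which 2 of the 2 values shown sit, so no step between measured compounds can be drawn. Within the data shown here, compound 2 stands at the limit with no number of its own, and the one further value shown is a limit as well.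

Compound 3 `O=C(COc1nc2ccccc2nc1/C=C\c1ccncc1)Nc1ccc(Cl)cc1` is the next compound for this assay. It differs from compound 2 by chloro in place of methyl on an aromatic carbon of a six-membered aromatic ring of carbon only, para to a large group; read one bond further out, 4-methylphenyl becomes 4-chlorophenyl. Compound 1 already carries the 4-chlorophenyl group and gives only a limit.

With both measured compounds at the limit, no step beyond the scatter is expected from compound 2 to compound 3, and compound 3 is expected to remain at the limit, with the step that the limit leaves unreadable from compound 2 to compound 3. For compound 3 the estimated value is 150000 nM, within 30000 nM to 1000000 nM.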

Compound 3, half-maximal inhibitory concentration: > 100000 nM
Compound 3 ended at the assay's limit; the forecaster's own chance of this, stated with the estimate: 85%; the middle value does not contradict the limit.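

In this assay compound 3 gives > 100000 nM, which is a limit. Within the data shown here, no step to compound 3 can be read from compound 1 or compound 2, because all three stand at the same limit: the limit of > 100000 nM in this assay, at which 3 of the 3 values shown sit. The compounds shown leave open whether chloro in place of methyl, or 2-(pyridin-4-yl)ethenyl in place of methyl, changes inhibition at all.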